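Removing a Trifluoromethyl Group from a Hydroxamic Acid Cap

The source may hold more compounds than are shown below. What is called first, only, known or untested is meant among the compounds shown, and "the series" means these compounds.

Compound 1, `O=C(CCC1=CCN(Cc2ccc(C(F)(F)F)cc2)C1=O)NO`: 3070 nM
Compound 2, `COc1ccc(CCCN2CC=C(CCC(=O)NO)C2=O)cc1`: 2560 nM

Both were tested in a functional assay on MDA-MB-231 cells (Homo sapiens) for antiproliferative activity; on this read-out lower numbers stand for stronger inhibition of growth and higher numbers for weaker inhibition of growth. Compound 1 has the higher of the two numbers, but compound 2 lies within the usual scatter of it, so neither can be called the stronger or weaker inhibitor. Compound 3, `O=C(CCC1=CCN(Cc2ccccc2)C1=O)NO`, has not yet been measured. It differs from compound 1 in a single place: hydrogen in place of trifluoromethyl on an aromatic carbon. For the measured compounds named here, no pair of measured compounds differs in just one place, so no comparable step is on hand for guidance. The expected step is a 1.3-fold higher number from compound 1 to compound 3 (0.11 log units; within the scatter), small and at most slightly toward weaker inhibition. Compound 3 is therefore expected to give about 4000 nM, within a range from 1500 nM to 11000 nM.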

Compound 3, concentration for 50% growth inhibition: 990 nM
For compound 3 the middle estimate is 4.0-fold (0.61 log units) above the measured one; measured number outside the range, below it.
By their numbers in this assay, from the lowest: compound 3; then compounds 2 and 1 (each within the scatter of the next).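

Hydrogen in place of trifluoromethyl on this aromatic carbon gives a 3.1-fold lower number from compound 1 to compound 3 (0.49 log units; beyond the scatter) in this assay, the only single-place step on hand. This shows that what sits at this position matters for growth inhibition, and that trifluoromethyl is not needed there for activity. Nothing measured here explains the gain.

From the compounds shown here alone, it remains open whether any group at this position would weaken growth inhibition or only trifluoromethyl does. A chlorine atom or a nitrile on the same carbon could separate these two possibilities.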